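The source may report more compounds than this note shows. Statements on the series, on what has been measured and on what is new or still open speak of the compounds shown alone.

Working notes on the series. Compound 1 `COc1cc2cc(NC(C)=O)c(=O)oc2cc1OCCOc1no[n+]([O-])c1S(=O)(=O)c1ccccc1` is one anchor; in an ADME assay on L02 cells (Homo sapiens) for cytotoxicity, read by MTT assay, with a stated time of 48 h (a higher number here means a weaker inhibitor, a lower number a stronger inhibitor), compound 1 gives 10300 nM. Compound 3 `COc1cc2cc(N)c(=O)oc2cc1OCCOc1no[n+]([O-])c1S(=O)(=O)c1ccccc1` carries the change (hydrogen in place of acetyl on a nitrogen on an aromatic ring); in this assay compound 3 gives 9820 nM, and the step of a 1.0-fold lower number from compound 1 to compound 3 (0.02 log units; within the scatter) is within the scatter. Compound 2 `COc1cc2cc(NC(C)=O)c(=O)oc2cc1OCCCOc1no[n+]([O-])c1S(=O)(=O)c1ccccc1` is the second anchor; in this assay compound 2 gives 8360 nM. The difference between the cores of compound 1 and compound 2 is not broken down here.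

Compound 4 `COc1cc2cc(N)c(=O)oc2cc1OCCCOc1no[n+]([O-])c1S(=O)(=O)c1ccccc1` has not been measured. It carries hydrogen in place of acetyl on a nitrogen on an aromatic ring, the same change seen from compound 1 to compound 3, at a place described in the same words. Among the measured compounds shown here, the step is expected to be a 1.0-fold lower number from compound 2 to compound 4 (0.01 log units; within the scatter), a repeat of a 1.0-fold lower number from compound 1 to compound 3 (0.02 log units; within the scatter), which is the only precedent. On that basis compound 4 is estimated at 8100 nM in this assay, expected between 4800 nM and 13500 nM.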

Compound 4, half-maximal inhibitory concentration: 9160 nM
Beside the measured number, compound 4's estimate is 1.1-fold (0.05 log units) below it; measured number inside the range.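

In this assay, the change from acetamido to amino on the core of compound 2 reads a 1.1-fold higher number from compound 2 to compound 4 (0.04 log units; within the scatter). Set beside the earlier step, the two agree: the same change on two cores in this assay, a 1.0-fold lower number (0.02 log units; within the scatter) from compound 1 to compound 3 and a 1.1-fold higher number (0.04 log units; within the scatter) from compound 2 to compound 4, 1.1-fold (0.06 log units) apart, within the scatter of two such steps. Among the compounds shown here, this shows that, on these two cores, the change gives no step that can be told from the scatter; it does not show how the change would read on a more distant core, and two steps that small cannot show that any real effect carries over.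

The compounds shown leave open whether other groups on that nitrogen, such as a methyl or a benzoyl, would give a larger step in this assay.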